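Single Stereocentre Inversion in an Iminosugar Acid

The source may hold more compounds than are shown below. What is called first, only, known or untested is meant among the compounds shown, and "the series" means these compounds.

Three compounds of one shared core, differing only in how their ring stereocentres are drawn, were tested in an assay for inhibition of alpha-N-acetylgalactosaminidase (Gallus gallus), tested at 1000 uM; on this read-out lower numbers stand for less inhibition and higher numbers for more inhibition at the one concentration tested (going by the name of the read-out). Compound 1 `O=C(O)[C@H]1NC[C@H](O)[C@H](O)[C@H]1O` gives 21%, the highest of the three numbers. Compound 2 `O=C(O)[C@@H]1NC[C@@H](O)[C@H](O)[C@@H]1O` gives 10%, and compound 3 `O=C(O)[C@@H]1NC[C@H](O)[C@@H](O)[C@H]1O` gives 4%. The step of a number 11 percentage points lower from compound 1 to compound 2 (beyond the scatter) and the step of a number 17 percentage points lower from compound 1 to compound 3 (beyond the scatter) both move downward beyond the scatter, while the step of a number 6 percentage points lower from compound 2 to compound 3 (within the scatter) stays within it. Only the configuration changes in each case the fact that compounds 1 and 2 differ only in the configuration as drawn the fact that compounds 1 and 3 differ only in the configuration as drawn (the fact that compounds 2 and 3 differ only in the configuration as drawn).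

Compound 4 `O=C(O)[C@H]1NC[C@@H](O)[C@H](O)[C@H]1O` is the next candidate. Compared with compound 1 it changes in one place: the two compounds have the same atoms and bonds and differ only in configuration as drawn: 1 of 4 stereo elements differ; a stereocentre at a saturated ring carbon is drawn S in compound 1 and R in compound 4. Both measured steps away from compound 1 involved inverting two or three centres and lowered the number; a single inversion is expected to lower it as well, probably by less. The expected step is a number 10 percentage points lower from compound 1 to compound 4 (within the scatter). Compound 4 is therefore estimated at 11% in this assay, with a range from 0% to 24%.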

Compound 4, a percentage reported as inhibition, at one concentration (the size of the read-out at that concentration, not a potency): 4.2%
Compound 4: the middle estimate sits 6.8 percentage points above what was measured, and the stated range covers the measured number.
By their numbers in this assay, from the lowest: compounds 3, 4 and 2 (each within the scatter of the next); then compound 1.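

In this assay, among these compounds, the earlier steps away from compound 1 each inverted two or three stereocentres, so they could not show what one centre does alone; here a single ring carbon, drawn S in compound 1 and R in compound 4, is enough to give a number 16.8 percentage points lower from compound 1 to compound 4 (beyond the scatter). The other two new steps, a number 5.8 percentage points lower from compound 2 to compound 4 (within the scatter) and a number 0.2 percentage points higher from compound 3 to compound 4 (within the scatter), place these three stereoisomers within the scatter of one another, so at this one concentration a single inversion reaches the same band as the multiple inversions. Only the drawn configuration separates the pair that shows this drop: the fact that compounds 1 and 4 differ only in the configuration as drawn.

On these data alone, whether the other ring stereocentres matter as much when each is inverted alone remains open, as does whether the same drop appears when a primary amide or a hydroxymethyl group replaces the carboxylic acid. As far as these compounds go, these single-concentration percentages are not potencies, so the true difference in potency between the stereoisomers also remains open.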